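Swapping the Ring on the Thiocarbonyl Carbon

A few compounds are considered here, and "the series" means these few. Any claim that something is new, unique, unknown or untested is made for them only; others in the source may bear on it.

Within the data shown here, in a functional assay on A-375 cells (Homo sapiens) for cytotoxicity, read by MTT assay, with a stated time of 72 h (on this read-out lower numbers stand for stronger inhibition and higher numbers for weaker inhibition), compound 1 `Cc1cccc(/C(N)=N/NC(=S)N2CCCCC2)n1` gives 1000 nM, the higher of the two numbers measured so far, while compound 2 `N/C(=N\NC(=S)N1CCCCC1)c1ccccn1` gives 680 nM. Among the measured compounds shown here, the single measured step, a 1.5-fold lower number from compound 1 to compound 2 (0.17 log units; within the scatter), concerns hydrogen in place of methyl on an aromatic carbon and leaves the ring on the thiocarbonyl carbon untouched. Compound 3 `Cc1cccc(/C(N)=N/NC(=S)N2CCOCC2)n1` differs from compound 1 by morpholin-4-yl in place of piperidin-1-yl on a thiocarbonyl carbon. For the measured compounds named here, no measured step bears on this exchange, so nothing beyond the scatter is expected in this assay. Compound 3 is therefore estimated at 1000 nM, with a range from 400 nM to 2500 nM. The expected step is no change at the digits printed from compound 1 to compound 3 (within the scatter).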

Compound 3, half-maximal inhibitory concentration: 14000 nM
For compound 3 the middle estimate is 14-fold (1.15 log units) below the measured one; the measured number lies above the stated range.
By their numbers in this assay, from the lowest: compounds 2 and 1 (each within the scatter of the next); then compound 3.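

In this assay, among these compounds, the group on the thiocarbonyl carbon proves sensitive to exchange: morpholin-4-yl in place of piperidin-1-yl gives a 14-fold higher number from compound 1 to compound 3 (1.15 log units; beyond the scatter), whereas the only earlier step stayed within the scatter. The entering ring differs by an oxygen and a hydrogen-bond acceptor, yet no available evidence accounts for the rise in the number. Open, from the compounds shown here alone, is whether piperazin-1-yl or thiomorpholin-4-yl on this carbon would follow morpholin-4-yl or piperidin-1-yl. Also open, going by these compounds, is whether the same exchange would give a similar step on the core of compound 2.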